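Phenyl for methyl beside the ring nitrogen of compound 2

The source may report more compounds than this note shows. Statements on the series, on what has been measured and on what is new or still open speak of the compounds shown alone.

Among the measured compounds shown here, compound 2 `CCN1C(=O)S/C(=C\c2ccc(N)cc2)C1=O` gives 108000 nM in a functional assay on HeLa cells (Homo sapiens) for cytotoxicity, read by cell counting, with a stated time of 4 days (on this read-out higher numbers stand for weaker inhibition and lower numbers for stronger inhibition), and stands highest of the three numbers so far. For the measured compounds named here, compound 1 `C=C(Br)C(=O)Nc1ccc(/C=C2\SC(=O)N(CC)C2=O)cc1` gives 1400 nM in this assay, and the single-point step a 77-fold higher number from compound 1 to compound 2 (1.89 log units; beyond the scatter) is the only measured step; it concerns the aniline nitrogen, not the nitrogen in the ring. Going by the values given here, compound 3 `C=C(Br)C(=O)Nc1cccc(/C=C2\SC(=O)N(Cc3ccc(F)cc3)C2=O)c1` gives 800 nM in this assay; compound 1 and compound 3 differ at the ring nitrogen and elsewhere, so their pair is no clean step, but their two values sit within the usual scatter of each other. Compound 4 `Nc1ccc(/C=C2\SC(=O)N(Cc3ccccc3)C2=O)cc1` has not been measured. It differs from compound 2 by phenyl in place of methyl on a saturated chain carbon bound to an amide-type nitrogen in a ring. Among the compounds with values here, no measured step isolates this change, and the only related pair, compound 1 against compound 3, shows no shift worth the name. The step of a 1.5-fold lower number from compound 2 to compound 4 (0.19 log units; within the scatter) in this assay is therefore expected to stay within the scatter, with a slight lean toward a lower number. Compound 4 is expected to give 70000 nM, within a range from 20000 nM to 250000 nM.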

Compound 4, half-maximal inhibitory concentration: 46000 nM
Compound 4: middle estimate off by 1.5-fold (0.18 log units), on the high side; low and high end bracket the measured number.
By their numbers in this assay, from the lowest: compounds 3 and 1 (each within the scatter of the next); then compound 4; then compound 2.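

Among the compounds shown here, the step of a 2.3-fold lower number from compound 2 to compound 4 (0.37 log units; beyond the scatter) gives the first clean reading of this change in this assay: phenyl in place of methyl on a saturated chain carbon bound to an amide-type nitrogen in a ring shifts the number modestly, but beyond the scatter. This step is much smaller than a 77-fold higher number from compound 1 to compound 2 (1.89 log units; beyond the scatter), so among these single changes, the larger shift remains the one at the nitrogen on an aromatic ring. No measurement bearing on the origin of the shift is available.

From the compounds shown here alone, whether ethyl to benzyl gives a similar step with (1-bromoethenyl)carbonyl on that nitrogen remains open, as compound 1 and compound 3 differ in more than one place. Going by these compounds, how a carboxylic acid, an amine or a longer chain would read in place of phenyl also remains open.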